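Cytotoxicity of acrylamide analogues on a shared chromone-type core

The compounds below may be only part of what the source reports. "The series", "measured", "known", "first", "only" and "open" are said of these compounds alone.

Measured so far in an ADME assay on HepG2 2.2.15 cells (Homo sapiens) for cytotoxicity, read by MTT assay, with stated times of 48 h and 9 days; a higher number here means that more compound is tolerated, a lower number that less compound is tolerated:
Compound 1, `COc1ccc2c(=O)c(/C=C/C(=O)Nc3cccc(Cl)c3)coc2c1`, gives 1100000 nM.
Compound 2, `COc1ccc(CNC(=O)/C=C/c2coc3cc(OC)ccc3c2=O)cc1`, gives 43000 nM.
Compound 3, `COc1ccc2c(=O)c(/C=C/C(=O)NCc3ccc(F)cc3)coc2c1`, gives 133000 nM.

Compound 3 stands second highest of the three numbers in this assay; its nearest neighbour is compound 2, with a 3.1-fold higher number from compound 2 to compound 3 (0.49 log units; beyond the scatter), and its furthest is compound 1, with an 8.3-fold lower number from compound 1 to compound 3 (0.92 log units; beyond the scatter).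

Compound 4, `CCOc1ccc(NC(=O)/C=C/c2coc3cc(OC)ccc3c2=O)cc1`, is not yet measured. It differs from compound 3 at the amide-type nitrogen, (4-ethoxyphenyl in place of 4-fluorobenzyl on an amide-type nitrogen).

Within the data shown here, two measured steps bear on this change. The step of an 8.3-fold lower number from compound 1 to compound 3 (0.92 log units; beyond the scatter) shows that an aryl group directly on the amide-type nitrogen was tolerated at a higher concentration than a benzyl group, and a 3.1-fold higher number from compound 2 to compound 3 (0.49 log units; beyond the scatter) shows that the alkoxy-bearing ring gave the lower number of the two benzyl amides. Since compound 4 returns an aryl group to that nitrogen while also carrying an alkoxy group, a rise is expected, though smaller than the full step back to compound 1, so the step of a 3.0-fold higher number from compound 3 to compound 4 (0.48 log units; beyond the scatter) is expected. Compound 4 is therefore estimated at 400000 nM, with a range from 100000 nM to 1200000 nM.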

Compound 4, half-maximal cytotoxic concentration: 460000 nM
For compound 4 the middle estimate is 1.2-fold (0.06 log units) below the measured one, and the stated range covers the measured number.
By their numbers in this assay, from the lowest: compound 2; then compound 3; then compound 4; then compound 1.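

Putting 4-ethoxyphenyl on the amide-type nitrogen gives a 3.5-fold higher number from compound 3 to compound 4 (0.54 log units; beyond the scatter) and an 11-fold higher number from compound 2 to compound 4 (1.03 log units; beyond the scatter) in this assay, so an alkoxy group on the ring does not by itself go with the low number of compound 2. Both phenyl amides, compound 1 and compound 4, now stand above both benzyl amides, compound 2 and compound 3, with none of the four against that order, yet the phenyl amides still differ, with a 2.4-fold lower number from compound 1 to compound 4 (0.38 log units; beyond the scatter) showing that the ring substituent also moves the number. Nothing at hand gives a reason for these steps.

Open, going by these compounds, is whether a longer chain such as phenethyl on that nitrogen extends the order. Also open, on these data alone, is how an unsubstituted phenyl, or a phenyl bearing a carboxylic acid or an amine, would compare with 4-ethoxyphenyl.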